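Swapping a Carbonyl for a Sulfonyl on Compound 2

This account rests on a few compounds, and the source may have more. Where it says the series, first, only, none or still open, it means among the compounds named here.

Compound 1 `O=S(=O)(Nc1ccc(-c2nc3cc(NS(=O)(=O)c4ccccc4Cl)ccc3o2)cc1)c1ccccc1Cl` at 12000 nM
Compound 2 `COc1ccc(S(=O)(=O)Nc2ccc3oc(-c4ccc(NC(=O)c5cccc(C)c5[N+](=O)[O-])cc4)nc3c2)cc1` at 4400 nM
Compound 3 `O=S(=O)(Nc1ccc(-c2nc3cc(NS(=O)(=O)c4cccc5ccccc45)ccc3o2)cc1)c1cccc2ccccc12` at 20000 nM

In a functional assay on HCT-116 cells (Homo sapiens) for cytotoxicity, read by resazurin assay, with a stated time of 48 h (on this read-out lower numbers stand for an effect already at smaller amounts and higher numbers for an effect only at larger amounts of compound), compound 2 gives 4400 nM as the lowest of the three numbers, and the gaps up to compound 1 and compound 3 both lie beyond the usual scatter. Compound 4 `COc1ccc(S(=O)(=O)Nc2ccc3oc(-c4ccc(NS(=O)(=O)c5cc(Br)ccc5OC)cc4)nc3c2)cc1` has not yet been measured. It differs from compound 2 in one place, with (5-bromo-2-methoxyphenyl)sulfonyl in place of (3-methyl-2-nitrophenyl)carbonyl on a nitrogen on an aromatic ring as the counted change. Going by the values given here, no two measured compounds differ in one place only, so the size of this step in this assay can be judged only loosely. Compound 1 at 12000 nM and compound 3 at 20000 nM also carry a sulfonyl group on that nitrogen, and on that basis a moderate step to a higher number is expected, only a little beyond the scatter. The expected change is a 2.3-fold higher number from compound 2 to compound 4 (0.36 log units; beyond the scatter) in size. The estimate for compound 4 is 10000 nM with an expected range from 3500 nM to 25000 nM in this measurement.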

Compound 4, half-maximal effective concentration: 12000 nM
Estimate against measurement, compound 4: 1.2-fold (0.08 log units) below; the measured number falls inside the stated range.
By their numbers in this assay, from the lowest: compound 2; then compounds 1, 4 and 3 (each within the scatter of the next).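

In this assay, going by these compounds alone, placing (5-bromo-2-methoxyphenyl)sulfonyl in place of (3-methyl-2-nitrophenyl)carbonyl on the nitrogen gives a 2.7-fold higher number from compound 2 to compound 4 (0.44 log units; beyond the scatter), the first step here in which only one place changes. The number at this position therefore moves even though the leaving and entering groups match in heavy atoms, aromatic rings, double bonds outside aromatic rings, hydrogen-bond donors and hydrogen-bond acceptors. Nothing available explains this step.

The carbonyl-to-sulfonyl swap and the change of ring groups arrive together, so the compounds shown leave open which of them carries the step. They also leave open how an amine or a carboxylic acid on the aromatic ring of this group would read in this assay.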